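One group swap from compound 3 to compound 4

The source may hold more compounds than are shown below. What is called first, only, known or untested is meant among the compounds shown, and "the series" means these compounds.

Measured in an ADME assay on Huh7.5.1 cells (Homo sapiens) for cytotoxicity, read by WST assay, with a stated time of 48 h (a higher number here means that more compound is tolerated, a lower number that less compound is tolerated), where each value is a limit of the assay:
- compound 1 `Cc1c(-c2ccc(Cc3ccc(OCC(F)(F)F)cc3)cc2)[nH]c2cccc(F)c2c1=O` gives > 5000 nM as its limit
- compound 2 `Cc1c(-c2ccc(Cc3ccc(S(=O)(=O)C(F)(F)F)cc3)cc2)[nH]c2cccc(F)c2c1=O` gives > 2500 nM as its limit
- compound 3 `Cc1c(-c2ccc(Oc3ccc(SC(F)(F)F)cc3)c(F)c2)[nH]c2cccc(F)c2c1=O` gives > 10000 nM as its limit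

Compound 3 therefore has no exact number, only a limit (> 10000 nM). Compound 4 `Cc1c(-c2ccc(Oc3ccc(N4CCCC4)cc3)c(F)c2)[nH]c2cccc(F)c2c1=O` differs from it in one group (pyrrolidin-1-yl in place of (trifluoromethyl)sulfanyl on an aromatic carbon). Here pyrrolidin-1-yl takes the place of (trifluoromethyl)sulfanyl on an aromatic carbon, para to a large group.

Within the data shown here, only one measured step bears on this, as it also swaps one group on an aromatic carbon: a step that the two limits leave unreadable from compound 1 to compound 2. Its size cannot be read, so it offers no guide to size or direction. No step beyond the usual scatter is therefore expected in this assay, and the expected change is a number no higher from compound 3 to compound 4 (the limit leaves the size open) as an estimate. For compound 4 the estimated value is 10000 nM, with an expected range from 3000 nM to 30000 nM as its ends.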

Compound 4, half-maximal cytotoxic concentration: > 10000 nM
Compound 4 gave a limit, no number; the forecaster's own chance of this, stated with the estimate: 65%; the middle value sits exactly at the limit.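

In this assay, among these compounds, compound 3 and compound 4 both give only a limit, and no step between them can be read. The compounds shown leave open whether pyrrolidin-1-yl in place of (trifluoromethyl)sulfanyl changes the concentration tolerated at all, and in which direction.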